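The source may hold more compounds than are shown below. What is called first, only, known or untested is meant among the compounds shown, and "the series" means these compounds.

Measured compounds:
Compound 1 `COc1ccc(-c2ss/c(=N/O)c2-c2cc(OC)c(OC)c(OC)c2)cc1`: 13700 nM
Compound 2 `COc1ccc(-c2ss/c(=N/O)c2-c2cc(OC)c(OC)c(OC)c2)cc1O`: 850 nM
Compound 3 `COc1ccc(-c2ss/c(=N/O)c2-c2cc(OC)c(OC)c(OC)c2)cc1N`: 99 nM

All three values come from a functional assay on KB cells (Homo sapiens) for antiproliferative activity, read by MTT assay, with a stated time of 72 h; a higher number here means a weaker inhibitor, a lower number a stronger inhibitor. Compound 2, at 850 nM, holds the second highest of the three numbers, with compound 3 its nearest neighbour and compound 1 the furthest away.

The next compound is compound 4 `CO/N=c1/ssc(-c2ccc(OC)c(O)c2)c1-c1cc(OC)c(OC)c(OC)c1`, and it departs from compound 2 as follows: methyl in place of hydrogen on an oxygen. In words, a methyl stands in place of a hydrogen on an oxygen whose other neighbour is a double-bonded nitrogen, so a hydroxy becomes a methoxy at that place.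

Going by the values given here, no measured step touches that oxygen. All three steps change an aromatic carbon: the large 16-fold lower number from compound 1 to compound 2 (1.21 log units; beyond the scatter), the large 140-fold lower number from compound 1 to compound 3 (2.14 log units; beyond the scatter) and the modest 8.6-fold lower number from compound 2 to compound 3 (0.93 log units; beyond the scatter). They show that the numbers in this assay can move far within this small set, but they say nothing direct about this change. The expectation is therefore no step beyond the scatter, held with a wide margin in both directions. The estimated change is a 1.4-fold higher number from compound 2 to compound 4 (0.15 log units; within the scatter). For compound 4 the expected value is 1200 nM, with an estimated range from 250 nM to 6000 nM.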

Compound 4, half-maximal inhibitory concentration: 14500 nM
Estimate against measurement, compound 4: 12-fold (1.08 log units) below, outside the stated range (above it).
By their numbers in this assay, from the lowest: compound 3; then compound 2; then compounds 1 and 4 (each within the scatter of the next).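

Going by these compounds alone, until now, every measured step had changed an aromatic carbon, and this is the first to touch the oxygen whose other neighbour is a double-bonded nitrogen. In this assay, methyl in place of hydrogen on that oxygen gives a 17-fold higher number from compound 2 to compound 4 (1.23 log units; beyond the scatter), so this place is far from silent, and a change of a single heavy atom here moves the number beyond the scatter. The step runs in the opposite direction to a 16-fold lower number from compound 1 to compound 2 (1.21 log units; beyond the scatter), and the data shown offer no measurement that accounts for the rise.

The compounds shown leave open whether the rise comes with any group on that oxygen or with methyl in particular, since a longer chain such as ethyl, or an acetyl group, does not appear among them at this place. They also leave open whether hydroxy to methoxy at this oxygen would carry the same size of step on the amino compound, compound 3, because the change is seen here only once, against the background of compound 2.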